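This account rests on a few compounds, and the source may have more. Where it says the series, first, only, none or still open, it means among the compounds named here.

Of the compounds shown here, three built on one shared core have been measured in an assay on CHO cells for displacement of a labelled ligand from adenosine receptor A1 (Homo sapiens), read by scintillation counting, with a stated time of 3 h; on this read-out lower numbers stand for stronger inhibition and higher numbers for weaker inhibition. Compound 1 `Cn1c(-c2ccc(F)cc2)nc2c(NC3CCCC3)ncnc21` gives 6.2 nM, compound 2 `Cn1c(-c2cccc(Cl)c2)nc2c(NC3CCCC3)ncnc21` gives 6.5 nM, and compound 3 `COc1ccc(-c2nc3c(NC4CCCC4)ncnc3n2C)cc1` gives 75 nM, which is the highest of the three numbers. The step of a 1.0-fold higher number from compound 1 to compound 2 (0.02 log units; within the scatter) lies within the scatter of the method, whereas a 12-fold higher number from compound 1 to compound 3 (1.08 log units; beyond the scatter) and a 12-fold higher number from compound 2 to compound 3 (1.06 log units; beyond the scatter) are both large losses of binding strength.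

Compound 4 `Cn1c(-c2ccc(C(=O)O)cc2)nc2c(NC3CCCC3)ncnc21` differs from compound 3 in a single place: carboxy in place of methoxy on an aromatic carbon. Within the data shown here, no measured step involves a carboxy group, so the data give no direct guide to its effect. Among the measured compounds shown here, what can be said is that the one measured change at this aromatic carbon, a 12-fold higher number from compound 1 to compound 3 (1.08 log units; beyond the scatter), was a large weakening, and compound 3 already stands at the weak end of the series. The carboxy group is expected to shift the number further in the same direction, by an estimated 4.0-fold higher number from compound 3 to compound 4 (0.60 log units; beyond the scatter). Compound 4 is therefore expected to give about 300 nM in this assay, within a range from 60 nM to 1500 nM.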

Compound 4, inhibition constant: 54000 nM
The estimate for compound 4 lay 180-fold (2.26 log units) below the measured number; the whole stated range lies below it.
By their numbers in this assay, from the lowest: compounds 1 and 2 (each within the scatter of the next); then compound 3; then compound 4.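

In this assay, among these compounds, the aromatic carbon para to a large group proves far more sensitive than the earlier compounds could reveal: carboxy in place of methoxy gives a 720-fold higher number from compound 3 to compound 4 (2.86 log units; beyond the scatter), and carboxy in place of fluoro gives an 8700-fold higher number from compound 1 to compound 4 (3.94 log units; beyond the scatter). The earlier change at this carbon, a 12-fold higher number from compound 1 to compound 3 (1.08 log units; beyond the scatter), looks modest beside these steps, so a large loss there was no ceiling on what a single group can cost. Carboxy also brings a hydrogen-bond donor that methoxy lacks, but no measurement at hand explains the size of this loss.

The compounds shown leave open whether so steep a loss belongs to carboxy alone or also extends to a primary amide, a methyl ester or an amine on this carbon. They also leave open whether carboxy would cost as much elsewhere on the same ring.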